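This account rests on a few compounds, and the source may have more. Where it says the series, first, only, none or still open, it means among the compounds named here.

Series notes. Compound 3 `c1cn2cc(-c3ccsc3)nc(-c3ccc4ncn(C5CCCCC5)c4c3)c2n1` is the starting point of this step. Within the data shown here, in a functional assay on SK-MEL-2 cells (Homo sapiens) for inhibition, read by sulforhodamine B assay, with a stated time of 48 h, tested at 10 uM (on this read-out higher numbers stand for more inhibition at the one concentration tested (going by the name of the read-out) and lower numbers for less inhibition), compound 3 gives 3.68%, the lowest of the three numbers so far. Compound 2 `Fc1ccc(-c2cn3ccnc3c(-c3ccc4ncn(C5CCCCC5)c4c3)n2)cc1`, which carries a 4-fluorophenyl group at the same place, gives 9.82% in this assay; compound 1 `O=Cc1ccc(-c2cn3ccnc3c(-c3ccc4ncn(C5CCCCC5)c4c3)n2)cc1`, with a 4-formylphenyl group there, gives 27.8%. The steps into compound 3 read a number 24.1 percentage points lower from compound 1 to compound 3 (beyond the scatter) and a number 6.1 percentage points lower from compound 2 to compound 3 (within the scatter), and the remaining step reads a number 18 percentage points lower from compound 1 to compound 2 (beyond the scatter), so both steps beyond the scatter involve compound 1, while the swap of 4-fluorophenyl for thiophen-3-yl stays within it.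

Compound 4 `COc1ccccc1-c1cn2ccnc2c(-c2ccc3ncn(C4CCCCC4)c3c2)n1` is not yet measured. It differs from compound 3 as follows: 2-methoxyphenyl in place of thiophen-3-yl on an aromatic carbon. The change brings back a six-membered aromatic ring of carbon only where compound 3 carries the thiophen-3-yl group, now with a methoxy group rather than a formyl group. Among the measured compounds shown here, the step most like it in kind is the one from compound 2 to compound 3 run backwards, which was within the scatter; no measured step shows a methoxy group at all. The expected step in this assay is therefore small, a number 6.3 percentage points higher from compound 3 to compound 4 (within the scatter), with no direction beyond the scatter. Compound 4 is expected to give 10% in this assay, with a range from 0% to 25%.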

Compound 4, a percentage reported as inhibition, at one concentration (the size of the read-out at that concentration, not a potency): 12.1%
Compound 4: middle estimate off by 2.1 percentage points, on the low side; low and high end bracket the measured number.
By their numbers in this assay, from the lowest: compounds 3, 2 and 4 (each within the scatter of the next); then compound 1.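

Compound 4 adds a methoxy group to the series, and in this assay it does not separate from the two low compounds: the data read a number 8.4 percentage points higher from compound 3 to compound 4 (within the scatter) and a number 2.3 percentage points higher from compound 2 to compound 4 (within the scatter), so thiophen-3-yl, 4-fluorophenyl and 2-methoxyphenyl cannot be told apart at this position. Among these compounds, the third comparison reads a number 15.7 percentage points lower from compound 1 to compound 4 (beyond the scatter), which leaves the 4-formylphenyl group of compound 1 as the only one of the four groups beyond the scatter from all the others, and shows that a substituted phenyl ring at this place does not by itself match compound 1. No measurement is available that explains why compound 1 stands apart from the other three.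

As far as these compounds go, it remains open whether the formyl group itself accounts for the gap, which a hydroxymethyl group, a carboxylic acid or an aminomethyl group on the same phenyl ring could test. From the compounds shown here alone, it also remains open whether moving the methoxy group to give 4-methoxyphenyl, or removing it to leave plain phenyl, would shift the number at this single concentration.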